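The compounds below may be only part of what the source reports. "The series", "measured", "known", "first", "only" and "open" are said of these compounds alone.

Compound 1 `O=C(N/N=C/c1ccccc1O)c1cc(-c2ccccc2)nn1Cc1ccc(Cl)nc1` and compound 2 `O=C(N/N=C/c1ccco1)c1cc(-c2ccccc2)nn1Cc1ccc(Cl)nc1` share one core. In a functional assay on A549 cells (Homo sapiens) for cytotoxicity, read by MTT assay, with a stated time of 48 h (on this read-out higher numbers stand for higher solubility and lower numbers for lower solubility), compound 1 gives 45000 nM, numerically the lowest of the two numbers, and compound 2 gives 50000 nM; the step of a 1.1-fold higher number from compound 1 to compound 2 (0.05 log units; within the scatter) stays inside the scatter. Compound 3 `COc1ccc(-c2cc(C(=O)N/N=C/c3ccccc3O)n(Cc3ccc(Cl)nc3)n2)cc1` differs from compound 1 by methoxy in place of hydrogen on an aromatic carbon, a methoxy in place of hydrogen on an aromatic carbon. Among the measured compounds shown here, no measured step touches this change; the only known step alters a different part of the molecule. The expected step is therefore no change at the digits printed from compound 1 to compound 3 (within the scatter), nothing beyond the scatter. In this assay compound 3 is estimated at 45000 nM, ranging from 25000 nM to 80000 nM.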

Compound 3, solubility: 70000 nM
Compound 3: the middle estimate sits 1.6-fold (0.19 log units) below what was measured; low and high end bracket the measured number.
By their numbers in this assay, from the lowest: compounds 1, 2 and 3 (each within the scatter of the next).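

Among the compounds shown here, the swap from phenyl to 4-methoxyphenyl gives a 1.6-fold higher number from compound 1 to compound 3 (0.19 log units; within the scatter) in this assay, and it is the first look at this ring, which the earlier step left untouched. At this position, para to a large group, methoxy in place of hydrogen therefore produces no step beyond the scatter. No supporting measurement bears on this result. Still open, from the compounds shown here alone, is whether an amine or a carboxylic acid at the same place would step beyond the scatter. Also open, going by these compounds, is whether methoxy reads the same alongside furan-2-yl in place of 2-hydroxyphenyl.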